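A few compounds are considered here, and "the series" means these few. Any claim that something is new, unique, unknown or untested is made for them only; others in the source may bear on it.

In an ADME assay on MT4 cells (Homo sapiens) for cytotoxicity, read by MTT assay (a lower number here means that less compound is tolerated, a higher number that more compound is tolerated), compound 3 `Cc1ccc(C(=O)N(C(=S)OCCN2C(=O)c3ccccc3C2=O)c2ccc(C)cc2)cc1` gives 83000 nM and compound 2 `Cc1ccc(N(C(=O)c2cccc([N+](=O)[O-])c2)C(=S)OCCN2C(=O)c3ccccc3C2=O)cc1` gives 100000 nM, two numbers within the scatter of each other. Compound 1 `Cc1ccc(C(=O)N(C(=S)OCCN2C(=O)c3ccccc3C2=O)c2ccc(Cl)cc2)cc1` gives > 100000 nM, which is a limit of the assay and not a number. Compound 4 `Cc1ccc(N(C(=O)c2ccc(F)cc2F)C(=S)OCCN2C(=O)c3ccccc3C2=O)cc1` differs from compound 3 by having 2,4-difluorophenyl in place of 4-methylphenyl on a carbonyl carbon. Exchanging the group at that same place gave a 1.2-fold lower number from compound 2 to compound 3 (0.08 log units; within the scatter), while methyl in place of chloro on an aromatic carbon gave an at least 1.2-fold lower number from compound 1 to compound 3 (0.08 log units; that floor lies within the scatter). With both steps within the scatter, no step beyond the scatter is expected in this assay here. The estimated step is a 1.0-fold lower number from compound 3 to compound 4 (0.02 log units; within the scatter). The expected value for compound 4 is 80000 nM, with an estimated range of 35000 nM to 100000 nM.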

Compound 4, half-maximal cytotoxic concentration: 20000 nM
Compound 4: middle estimate off by 4.0-fold (0.60 log units), on the high side; the whole stated range lies above it.
By their numbers in this assay, from the lowest: compound 4; then compounds 3 and 2 (each within the scatter of the next).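

Until now, swapping the group on this carbonyl carbon had stayed within the scatter, yet in this assay it can matter: 2,4-difluorophenyl brings the tolerated concentration down clearly (a 4.2-fold lower number from compound 3 to compound 4 (0.62 log units; beyond the scatter)) and (a 5.0-fold lower number from compound 2 to compound 4 (0.70 log units; beyond the scatter)). So less compound is tolerated with this group than with 4-methylphenyl or 3-nitrophenyl. Compound 1 stands at a limit, so its step says little about how far the numbers can move: the limit of > 100000 nM in this assay, at which 1 of the 4 values shown sits.

Still open, on these data alone, is whether a single fluorine on the phenyl ring would have the same effect. Also open, as far as these compounds go, is how a phenyl ring carrying an amine or a carboxylic acid would fare here.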